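A few compounds are considered here, and "the series" means these few. Any claim that something is new, unique, unknown or untested is made for them only; others in the source may bear on it.

Compound 1, `Cc1cc(OCc2c(-c3c(Cl)cccc3Cl)noc2C(C)C)ncc1[N+](=O)[O-]`, in a functional assay on HEK293 cells for agonist activity at Bile acid receptor (Homo sapiens), read by a luciferase reporter (on this read-out higher numbers stand for larger maximal responses and lower numbers for smaller maximal responses), gives 76%.
Compound 2, `CC(c1ccc(OCc2c(-c3c(Cl)cccc3Cl)noc2C2CC2)nc1C(F)(F)F)N(C)c1ccc(C(=O)O)cc1`, in this assay gives 57%.

Among the compounds with values here, of the two compounds measured so far, compound 2 stands lowest; the nearest number is that of compound 1, which lies higher by a margin beyond the usual scatter, so the two compounds are genuinely told apart by this read-out. The two share a core built around the same isoxazole fragment bearing the dichlorophenyl group, but they differ in several places at once, so no single change can be read from their gap.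

Compound 3, `CC(Oc1cccc(C(=O)O)c1)c1ccc(OCc2c(-c3c(Cl)cccc3Cl)noc2C2CC2)nc1C(F)(F)F`, has not yet been measured. It differs from compound 2 in one place: 3-carboxyphenoxy in place of (4-carboxyphenyl)(methyl)amino on a saturated chain carbon bound to an aromatic carbon and a saturated chain carbon. Within the data shown here, no pair of measured compounds shows the effect of such a change, so nothing here says which way the number should move. For compound 3 the step of a number 2 percentage points lower from compound 2 to compound 3 (within the scatter) is expected to stay within the scatter. Compound 3 is therefore estimated at 55%, with a range from 35% to 80%.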

Compound 3, largest response reached (reported as efficacy), in percent of the reference or control that the assay uses: 49%
For compound 3 the middle estimate is 6 percentage points above the measured one; the range from low to high includes it.
By their numbers in this assay, from the lowest: compounds 3 and 2 (each within the scatter of the next); then compound 1.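

Within the data shown here, compounds 2 and 3 are the first pair here that differ in one place, so a single change can be read in this assay: 3-carboxyphenoxy in place of (4-carboxyphenyl)(methyl)amino on a saturated chain carbon bound to an aromatic carbon and a saturated chain carbon gives a number 8 percentage points lower from compound 2 to compound 3 (within the scatter). At this position, then, the read-out does not tell these two groups apart. Nothing available here bears on why the two groups match.

On these data alone, this one exchange alters both the atom linking the group to the chain and the arrangement on the carboxyphenyl ring, so the share of each stays open. Also open, as far as these compounds go, is how the maximal response would stand with a primary amide in place of the carboxylic acid.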